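Amide-linked coumarin series: amine terminus variation on the ether chain

The compounds below may be only part of what the source reports. "The series", "measured", "known", "first", "only" and "open" are said of these compounds alone.

Compound 1 `CC(=O)Oc1ccc(C(=O)Nc2cc3ccc(OCC4CCCN(C)C4)c(C)c3oc2=O)cc1CC=C(C)C`: in a functional assay on SK-BR-3 cells (Homo sapiens) for antiproliferative activity (on this read-out lower numbers stand for stronger inhibition and higher numbers for weaker inhibition), compound 1 gives 740 nM.
Compound 2 `CC(=O)Oc1ccc(C(=O)Nc2cc3ccc(OCC4CCN(C)C4)c(C)c3oc2=O)cc1CC=C(C)C`: in this assay compound 2 gives 880 nM.
Compound 3 `CCN(C)CCCOc1ccc2cc(NC(=O)c3ccc(O)c(CC=C(C)C)c3)c(=O)oc2c1C`: in this assay compound 3 gives 730 nM.

The three values sit close together. Compound 3 has the lowest number, but its gap to compound 1 and to compound 2 lies within the scatter, so no order among them can be claimed. Going by the values given here, the one single-place step measured, a 1.2-fold higher number from compound 1 to compound 2 (0.08 log units; within the scatter), also falls within the scatter.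

Compound 4 `CC(C)=CCc1cc(C(=O)Nc2cc3ccc(OCCCNCC(N)=O)c(C)c3oc2=O)ccc1O` differs from compound 3 only at the end of the ether chain: (carbamoylmethyl)amino in place of ethyl(methyl)amino on a saturated chain carbon, three bonds along the chain from an oxygen on an aromatic ring. Among the compounds with values here, no measured step touches this part of the chain in the same way; the step from compound 1 to compound 2 changed the ring carried by the chain, not an open-chain amine, and left the number nearly unchanged. With nothing to anchor a larger shift, the expectation for compound 4 in this assay is a step of a 1.6-fold higher number from compound 3 to compound 4 (0.22 log units; within the scatter). Within the data shown here, the range is kept wide, as no measured step bears on this change. Compound 4 is therefore estimated at 1200 nM, with a range from 400 nM to 3600 nM.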

Compound 4, half-maximal inhibitory concentration: 2290 nM
Compound 4: middle estimate off by 1.9-fold (0.28 log units), on the low side, within the range that was stated.
By their numbers in this assay, from the lowest: compounds 3, 1 and 2 (each within the scatter of the next); then compound 4.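

At the end of the ether chain, the open-chain amine matters in this assay: (carbamoylmethyl)amino in place of ethyl(methyl)amino gives a 3.1-fold higher number from compound 3 to compound 4 (0.50 log units; beyond the scatter), the only step shown so far that lies beyond the scatter. The step at the ring carried by the chain, a 1.2-fold higher number from compound 1 to compound 2 (0.08 log units; within the scatter), showed no such sensitivity, although it changed a different part of the chain terminus and so sets no general rule for it. The change replaces a group with 0 hydrogen-bond donors by one with 2, but no measurement in hand ties the weaker inhibition to that difference or to any other property.

The compounds shown do not separate the effect of the carbamoyl part from that of the amine left on the chain. A plain methylamino group or a carboxylic acid at the same chain end would bear on that, and a longer chain carrying (carbamoylmethyl)amino would test how far the effect depends on chain length.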